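The compounds below may be only part of what the source reports. "The series", "measured", "known", "first", "only" and "open" are said of these compounds alone.

Measured so far:
- compound 1, `Cc1nn(C)c2nc(NNC(=O)Nc3cc(Cl)nc(Cl)c3)cc(C3CCCCC3)c12`: 38000 nM
- compound 2, `CCCCOc1cc(NC(=O)NNc2cc(-c3ccc(OC)cc3)c3cnn(C)c3n2)cc(Cl)n1`: 36500 nM

Both compounds were tested in a functional assay on HCT-116 cells (Homo sapiens) for cytotoxicity, read by MTT assay, with a stated time of 48 h, in the presence of a further agent that is not named here; on this read-out lower numbers stand for an effect already at smaller amounts and higher numbers for an effect only at larger amounts of compound. Compound 1 gives 38000 nM, the higher of the two numbers, but its nearest neighbour, compound 2 with 36500 nM, sits so close that the two values fall within the usual scatter of this kind of measurement and cannot be told apart. Both compounds therefore show an effect only at large amounts.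

Compound 3, `Cc1nn(C)c2nc(NNC(=O)Nc3cc(Cl)nc(Cl)c3)cc(-c3ccc(F)cc3)c12`, has not yet been measured. It differs from compound 1 in one place: 4-fluorophenyl in place of cyclohexyl on an aromatic carbon. Going by the values given here, the only measured compound that also carries an aromatic group at this part of the shared core is compound 2, whose value in this assay matches that of compound 1 within the scatter. On this slim basis the expected step of a 1.1-fold lower number from compound 1 to compound 3 (0.04 log units; within the scatter) is none beyond the scatter, in either direction. Compound 3 is accordingly estimated to give 35000 nM in this assay, within a range from 15000 nM to 80000 nM.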

Compound 3, half-maximal effective concentration: 25200 nM
The estimate for compound 3 lay 1.4-fold (0.14 log units) above the measured number, within the range that was stated.
By their numbers in this assay, from the lowest: compounds 3, 2 and 1 (each within the scatter of the next).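

In this assay, going by these compounds alone, the change from cyclohexyl to 4-fluorophenyl on this aromatic carbon of the shared core gives a 1.5-fold lower number from compound 1 to compound 3 (0.18 log units; within the scatter), so this pair offers the first direct look at this position, and the step cannot be told apart from repeat-to-repeat variation. For this one pair, then, a non-aromatic ring of carbon and an aromatic ring carrying fluorine at this place leave the number unchanged within the scatter, and both compounds still show an effect only at large amounts. No measurement at hand gives a reason for this result.

The change also swaps two features at once, the ring type and the added fluorine, so a plain phenyl group would be needed to look at each separately. Even a clear outcome of that comparison would speak only for this position on this core. Also open, on these data alone, is whether a group of a quite different kind here, such as an amine, a carboxylic acid or a longer chain, would move the number beyond the scatter.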